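Aryl sulfone swap on the indazole-sulfonyl piperazine series

This account rests on a few compounds, and the source may have more. Where it says the series, first, only, none or still open, it means among the compounds named here.

Compound 1 `Cn1nc(S(=O)(=O)c2ccccc2)c2cc(N3CCNCC3)ccc21` and compound 2 `CN1CCN(c2ccc3[nH]nc(S(=O)(=O)c4c(Cl)cccc4Cl)c3c2)CC1` share a core and are read in a functional assay on HeLa cells for antagonist activity at 5-hydroxytryptamine receptor 6 (Homo sapiens); on this read-out lower numbers stand for stronger inhibition and higher numbers for weaker inhibition. In this assay compound 1 gives 3.2 nM, while compound 2 gives 40 nM, the higher of the two numbers; the two compounds differ in more than one place, so the comparison only shows that compound 2 sits at the weaker end of what has been measured so far. The next compound, compound 3 `CN1CCN(c2ccc3[nH]nc(S(=O)(=O)c4cccs4)c3c2)CC1`, keeps the methylpiperazine and the unmethylated core of compound 2 and changes only the sulfonyl aryl group: thiophen-2-yl in place of 2,6-dichlorophenyl on a sulfonyl sulfur. Going by the values given here, no single-change step has yet been measured, so the direction is open. The expectation for compound 3 is a modestly lower number, estimated at 15 nM with a range of 4 nM to 60 nM. The step this estimate implies is expected to be a 2.7-fold lower number from compound 2 to compound 3 (0.43 log units; beyond the scatter).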

Compound 3, half-maximal inhibitory concentration: 331 nM
Compound 3: the middle estimate sits 22-fold (1.34 log units) below what was measured, and the stated range ends below it.
By their numbers in this assay, from the lowest: compound 1; then compound 2; then compound 3.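

Thiophen-2-yl in place of 2,6-dichlorophenyl on a sulfonyl sulfur gives an 8.3-fold higher number from compound 2 to compound 3 (0.92 log units; beyond the scatter) in this assay and is the first single-change step in the series, so the sulfonyl aryl group is a place where the read-out moves beyond the usual scatter, and here 2,6-dichlorophenyl is the better of the two groups. The swap alters ring size, the chlorine atoms and the ring hetero atom together, so this one step cannot assign the change to any of them. Nothing at hand bears on why the number rises.

Open, on these data alone, is whether a 2-chlorophenyl or a pyridin-3-yl on the sulfonyl sulfur would read nearer compound 2 or compound 3. Also open, as far as these compounds go, is how the same aryl swap behaves on the core of compound 1, which differs from compound 2 in more than one place.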